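Same amino change tested on a second core

The compounds below may be only part of what the source reports. "The series", "measured", "known", "first", "only" and "open" are said of these compounds alone.

Compound 1 `ClCc1ccc(Cn2cnc3c(Cl)ncnc32)cc1`: 1820 nM
Compound 2 `Nc1nc(Cl)c2ncn(Cc3ccc(CCl)cc3)c2n1`: 21400 nM
Compound 3 `ClCc1ccccc1Cn1cnc2c(Cl)ncnc21`: 3980 nM

These three compounds were tested in a functional assay on NCI-H322M cells (Homo sapiens) for cytotoxicity, read by sulforhodamine B assay, with a stated time of 48 h; a lower number here means a stronger inhibitor of growth, a higher number a weaker inhibitor of growth. Compound 1 and compound 2 differ by one change, (amino in place of hydrogen on an aromatic carbon), which gave a 12-fold higher number from compound 1 to compound 2 (1.07 log units; beyond the scatter). Compound 3 has the same atoms as compound 1 joined differently; the difference between the two cores is not broken down here. Compound 3 gives a higher number than compound 1 and a lower number than compound 2 in this assay.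

Compound 4 `Nc1nc(Cl)c2ncn(Cc3ccccc3CCl)c2n1` has not yet been measured. It arises from compound 3 by the same change, (amino in place of hydrogen on an aromatic carbon), at the same kind of place. Because the earlier step was a 12-fold higher number from compound 1 to compound 2 (1.07 log units; beyond the scatter), a step of similar size is expected for compound 4, giving an estimated 10-fold higher number from compound 3 to compound 4 (1.00 log units; beyond the scatter). Compound 4 is therefore expected to give about 40000 nM in this assay, with a likely range from 12000 nM to 120000 nM.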

Compound 4, concentration for 50% growth inhibition: 12300 nM
The estimate for compound 4 lay 3.3-fold (0.51 log units) above the measured number; the measured number falls inside the stated range.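

In this assay, putting the amino group on the second core again gave a weaker inhibitor of growth, with a 3.1-fold higher number from compound 3 to compound 4 (0.49 log units; beyond the scatter). The direction of the change carried over from the core of compound 1 to the core of compound 3, but its size did not: the same change on two cores in this assay, a 12-fold higher number (1.07 log units; beyond the scatter) from compound 1 to compound 2 and a 3.1-fold higher number (0.49 log units; beyond the scatter) from compound 3 to compound 4, 3.8-fold (0.58 log units) apart, beyond the scatter of two such steps. Two pairs cannot show why the size differs, nor how the change would behave on any further core.

The compounds shown leave open how another group on the aromatic carbon between two ring nitrogen atoms, such as a methylamino group or a hydroxyl group, would compare with amino. They also leave open whether either core would respond to such a group in the same direction.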